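Replacing a tert-butyl group with methoxy

A few compounds are considered here, and "the series" means these few. Any claim that something is new, unique, unknown or untested is made for them only; others in the source may bear on it.

In a functional assay on Hep 3B2 cells (Homo sapiens) for cytotoxicity, read by MTT assay, with a stated time of 6 days (a lower number here means a stronger inhibitor, a higher number a weaker inhibitor), three compounds have been measured so far. Compound 1 (`COc1ccc2c(c1)OCC(=O)N2Cc1cn(Cc2ccccc2)nn1`) gives 9200 nM and compound 2 (`CCOC(=O)c1ccc2c(c1)N(Cc1cn(Cc3ccccc3)nn1)C(=O)CO2`) gives 17100 nM in this test. Compound 3 (`CC(C)(C)c1ccc(Cn2cc(CN3C(=O)COc4ccccc43)nn2)cc1`) gives 25600 nM which lies within the usual scatter of compound 2 but is beyond the scatter from compound 1, as the weaker of that pair.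

Compound 4 (`COc1ccc(Cn2cc(CN3C(=O)COc4ccccc43)nn2)cc1`) carries methoxy in place of tert-butyl on an aromatic carbon. For the measured compounds named here, no measured pair shows this change directly. Compound 1, at 9200 nM also carries a methoxy group, but elsewhere, so it is only a faint hint. The expected change, a 1.6-fold lower number from compound 3 to compound 4 (0.20 log units; within the scatter) stays within the scatter. For compound 4 the expected value is 16000 nM and the estimated range runs from 7000 nM up to 35000 nM as a plausible span.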

Compound 4, half-maximal inhibitory concentration: > 100000 nM
Compound 4: a limit, no number (the forecaster's own chance of this, stated with the estimate: 10%); at least 6.2-fold (0.79 log units) between middle value and limit.
By their numbers in this assay, from the lowest: compounds 1, 2 and 3 (each within the scatter of the next, the first and the last beyond it). At a limit, above all of these: compound 4.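

Swapping tert-butyl for methoxy on this aromatic carbon gives an at least 3.9-fold higher number from compound 3 to compound 4 (0.59 log units; beyond the scatter), so the group at this position matters, and methoxy here gives the weaker compound. For the compounds shown here, this is the first change made in one place only, and its full size remains unknown. Compound 4 reads > 100000 nM, which is a limit and not a number: the limit of > 100000 nM in this assay, at which 1 of the 4 values shown sits.

The compounds shown leave open how other groups at this position, such as an amine, a carboxylic acid or a longer chain, would compare with tert-butyl. They also leave open whether a methoxy group behaves the same way on other cores.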